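This account rests on a few compounds, and the source may have more. Where it says the series, first, only, none or still open, it means among the compounds named here.

Series notes. Compound 1 `CCc1cc(C(=O)OC)c(NC(=O)c2ccc([N+](=O)[O-])o2)s1`, compound 2 `CCCCOC(=O)c1cc(CC)sc1NC(=O)c1ccc([N+](=O)[O-])o1` and compound 3 `CCc1cc(C(N)=O)c(NC(=O)c2ccc([N+](=O)[O-])o2)s1` share one core and differ only in the group carried on a carbonyl carbon. In an ADME assay on HeLa cells (Homo sapiens) for cytotoxicity, read by resazurin assay, with a stated time of 65 h (a lower number here means that less compound is needed, a higher number that more compound is needed for the effect), compound 1 gives > 20000 nM, which is a limit of the assay and not a number. In this assay compound 2 gives > 20000 nM, again a limit. In this assay compound 3 gives > 20000 nM, also a limit. Compound 3 thus stands at the limit of > 20000 nM in this assay, at which 3 of the 3 values shown sit, together with the two others. The steps a step that the two limits leave unreadable from compound 1 to compound 2, a step that the two limits leave unreadable from compound 1 to compound 3 and a step that the two limits leave unreadable from compound 2 to compound 3 are all unreadable in size; each joins two limits.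

Compound 4 `CCc1cc(C(=O)O)c(NC(=O)c2ccc([N+](=O)[O-])o2)s1` is the next member, still to be measured in this assay. It differs from compound 3 by hydroxy in place of amino on a carbonyl carbon. Going by the values given here, no measured step bears on this change in a readable way; the three known steps show only that every measured compound sits at the limit. Compound 4 is expected to stay at the limit as well, the estimated step that the limit leaves unreadable from compound 3 to compound 4 being unreadable against the scatter. Compound 4 is estimated at 30000 nM, with a range from 15000 nM to 60000 nM.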

Compound 4, half-maximal effective concentration: > 20000 nM
Compound 4 gave a limit, no number; the forecaster's own chance of this, stated with the estimate: 85%; the middle value is on the limit's open side.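

No new step can be read from compound 1, compound 2 or compound 3 to compound 4, as each joins two limits, and all four compounds stand together: the limit of > 20000 nM in this assay, at which 4 of the 4 values shown sit. The compounds shown leave open whether any group on the carbonyl carbon gives a number in this assay.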